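The compounds below may be only part of what the source reports. "The series", "measured", "known", "first", "only" and "open" are said of these compounds alone.

Measured compounds:
- compound 1 `Fc1ccccc1C1Cc2nccn2C1`: 301 nM
- compound 2 `FC(F)Oc1ccccc1C1Cc2nccn2C1`: "not determined" (no result reported)

In a functional assay on CHO cells for agonist activity at Alpha-1D adrenergic receptor (Homo sapiens), read by FLIPR and calcium flux (a higher number here means that more compound is needed for the effect, a lower number that less compound is needed), compound 1 gives 301 nM. For compound 2 the record holds no number: in this assay compound 2 shows "not determined" (no result reported), so there is no value from which a step could be counted, and compound 2 stands nowhere on the scale that compound 1 occupies.

Compound 3 `Clc1ccccc1C1Cc2nccn2C1` differs from compound 2 in one place: chloro in place of difluoromethoxy on an aromatic carbon. Within the data shown here, with no starting number for compound 2, the size and direction of the step from compound 2 to compound 3 cannot be expected from the data; the only anchor is the value of compound 1 in this assay, which shares the core and the site of substitution.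

On that basis compound 3 is estimated to fall near compound 1, at 250 nM, within a range of 80 nM to 800 nM.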

Compound 3, half-maximal effective concentration: 364 nM
For compound 3 the middle estimate is 1.5-fold (0.16 log units) below the measured one; low and high end bracket the measured number.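

Exchanging fluoro for chloro on this aromatic carbon gives a 1.2-fold higher number from compound 1 to compound 3 (0.08 log units; within the scatter) in this assay, so the two compounds cannot be told apart in this assay, and this place holds a second measured group with a reading level with the first. The step from compound 2 to compound 3 cannot be read, and the difluoromethoxy group therefore remains unplaced against either halogen. Nothing in hand offers an explanation for the result.

The compounds shown leave open whether a group that is not a halogen at this place, such as an amine, a carboxylic acid or a longer chain, would give a number beyond the scatter. They also leave open whether chloro or fluoro on another carbon of the same aromatic ring would read as these two do.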